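Alkyl chain isomers on the shared core: no measurable activity

The source may hold more compounds than are shown below. What is called first, only, known or untested is meant among the compounds shown, and "the series" means these compounds.

Compound 2 `CCC(C)n1cnc2ncnc(N)c21` carries a sec-butyl group on the ring nitrogen of the shared core. In a functional assay on CHO cells for antagonist activity at adenosine receptor A2b (Homo sapiens) (on this read-out lower numbers stand for stronger inhibition and higher numbers for weaker inhibition), compound 2 gives > 30000 nM, which is a limit of the assay rather than a number. The other measured compound, compound 1 `CC(C)n1cnc2ncnc(N)c21`, carries isopropyl at the same place; in this assay compound 1 gives > 30000 nM, again a limit. The step between them, a step that the two limits leave unreadable from compound 1 to compound 2, cannot be read from two limits. Compound 3 `CC(C)Cn1cnc2ncnc(N)c21` is the next member: isobutyl in place of sec-butyl on an aromatic nitrogen; the two have the same atoms, joined differently. Among the compounds with values here, the only measured step that bears on this change is the unreadable one, so its size gives no guidance; what the numbers do show is the limit of > 30000 nM in this assay, at which 2 of the 2 values shown sit. No step beyond the scatter is therefore expected for compound 3, which is expected to stay outside the measurable range, with a step that the limit leaves unreadable from compound 2 to compound 3 as the expected move. Compound 3 is estimated at 50000 nM, within 15000 nM to 200000 nM.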

Compound 3, inhibition constant: > 30000 nM
Compound 3 was reported as a limit (the forecaster's own chance of this, stated with the estimate: 85%); the middle value lies beyond the limit too.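

Compound 1, compound 2 and compound 3 all sit at a limit of this assay, so no step among them can be read: the limit of > 30000 nM in this assay, at which 3 of the 3 values shown sit.

The compounds shown leave open whether any alkyl chain on this aromatic nitrogen of the shared core gives a measurable value, and how isopropyl, sec-butyl and isobutyl compare.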